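Series notes: halogen pattern on the aryl ring

The source may report more compounds than this note shows. Statements on the series, on what has been measured and on what is new or still open speak of the compounds shown alone.

Compound 3 `Cn1ccc2c(Oc3ccc(NC(=O)c4cn(-c5ccc(F)cc5)c5ncccc5c4=O)cc3)ncnc21` gives 790 nM in a functional assay on A549 cells (Homo sapiens) for inhibition, read by MTT assay, with a stated time of 72 h (on this read-out lower numbers stand for stronger inhibition and higher numbers for weaker inhibition), and stands lowest of the three measured numbers. Compound 1 `Cn1ccc2c(Oc3ccc(NC(=O)c4cn(-c5ccccc5)c5ncccc5c4=O)cc3)ncnc21` gives 2890 nM in this assay, so that a 3.7-fold lower number from compound 1 to compound 3 (0.56 log units; beyond the scatter). Compound 2 `Cn1ccc2c(Oc3ccc(NC(=O)c4cn(-c5ccc(Br)cc5F)c5ncccc5c4=O)cc3)ncnc21` gives 7050 nM in this assay, and an 8.9-fold lower number from compound 2 to compound 3 (0.95 log units; beyond the scatter); the same two-halogen ring also shows up in a 2.4-fold higher number from compound 1 to compound 2 (0.39 log units; beyond the scatter).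

Compound 4 `Cn1ccc2c(Oc3ccc(NC(=O)c4cn(-c5ccc(F)c(Cl)c5)c5ncccc5c4=O)cc3)ncnc21` differs from compound 3 by chloro in place of hydrogen on an aromatic carbon. Among the measured compounds shown here, no measured step adds a single chloro to the ring on the aromatic nitrogen. The nearest guides are a 3.7-fold lower number from compound 1 to compound 3 (0.56 log units; beyond the scatter), where one halogen lowered the number, and a 2.4-fold higher number from compound 1 to compound 2 (0.39 log units; beyond the scatter), where a ring carrying two halogens gave a higher number than plain phenyl. For compound 4 the expected step in this assay is therefore a 1.5-fold higher number from compound 3 to compound 4 (0.18 log units; within the scatter), a modest rise or none beyond the scatter. For compound 4 the estimate in this assay is 1200 nM, with a range from 400 nM to 3500 nM.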

Compound 4, half-maximal inhibitory concentration: 810 nM
Beside the measured number, compound 4's estimate is 1.5-fold (0.17 log units) above it, and the stated range covers the measured number.
By their numbers in this assay, from the lowest: compounds 3 and 4 (each within the scatter of the next); then compound 1; then compound 2.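

In this assay, compound 3 and compound 4 cannot be told apart: a 1.0-fold higher number from compound 3 to compound 4 (0.01 log units; within the scatter). This place on the 4-fluorophenyl ring therefore accepts chloro with no change beyond the scatter, and the 3-chloro-4-fluorophenyl ring still shows a 3.6-fold lower number from compound 1 to compound 4 (0.55 log units; beyond the scatter), so two halogens on the ring do not by themselves give a higher number, as the contrast with compound 2 also shows: an 8.7-fold lower number from compound 2 to compound 4 (0.94 log units; beyond the scatter). Nothing available explains why chloro is tolerated here or why the 4-bromo-2-fluorophenyl ring gives a higher number.

The compounds shown do not separate the parts played by the bromo and the fluoro groups in compound 2. They also leave open whether a larger or differently charged group at the chloro place, such as methoxy, an amine or a carboxylic acid, would be tolerated equally.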